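A few compounds are considered here, and "the series" means these few. Any claim that something is new, unique, unknown or untested is made for them only; others in the source may bear on it.

Measured compounds:
compound 1 `CCc1ccc(S(=O)(=O)NCCC[C@H]2C(=O)N(c3ccc(C)cc3)[C@@H]2c2ccc(NS(C)(=O)=O)cc2)cc1` — > 100000 nM
compound 2 `CCc1ccc(S(=O)(=O)NCCC[C@H]2C(=O)N(c3ccc(C)cc3)[C@@H]2c2ccc(NS(=O)(=O)c3ccc(C)cc3)cc2)cc1` — 42900 nM
compound 3 `Cc1ccc(N2C(=O)[C@H](CCCNS(=O)(=O)c3ccc(OC(F)(F)F)cc3)[C@H]2c2ccc(NS(C)(=O)=O)cc2)cc1` — > 100000 nM

In an ADME assay on HEK293 cells (Homo sapiens) for cytotoxicity, read by MTT assay, with a stated time of 48 h (a higher number here means that more compound is tolerated, a lower number that less compound is tolerated), compound 1 gives only a limit, > 100000 nM. Compound 3 likewise gives only a limit in this assay, > 100000 nM. Within the data shown here, compound 2 is the one compound with a number in this assay, 42900 nM.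

The change from compound 1 to compound 2 is 4-methylphenyl in place of methyl on a sulfonyl sulfur; it made the step of an at least 2.3-fold lower number from compound 1 to compound 2 (0.36 log units; beyond the scatter). The cores of compound 1 and compound 3 differ by trifluoromethoxy in place of ethyl on an aromatic carbon; the step that the two limits leave unreadable from compound 1 to compound 3 cannot be sized due to the limit of > 100000 nM in this assay, at which 2 of the 3 values shown sit.

Compound 4 `Cc1ccc(N2C(=O)[C@H](CCCNS(=O)(=O)c3ccc(OC(F)(F)F)cc3)[C@H]2c2ccc(NS(=O)(=O)c3ccc(C)cc3)cc2)cc1` is not yet measured. It differs from compound 3 by 4-methylphenyl in place of methyl on a sulfonyl sulfur, the same change as from compound 1 to compound 2, at a sulfonyl sulfur whose other neighbour is a sulfonamide nitrogen in both pairs. Among the measured compounds shown here, the expectation for this assay is that compound 4 shows a step of an at least 2.2-fold lower number from compound 3 to compound 4 (0.34 log units; beyond the scatter), resting on the step of an at least 2.3-fold lower number from compound 1 to compound 2 (0.36 log units; beyond the scatter) of the one pair where the change was measured. Compound 4 is thus estimated at 45000 nM in this assay, with a range from 20000 nM to 100000 nM.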

Compound 4, concentration lethal to 50% of the cells in the HEK293 assay: > 100000 nM
Compound 4 ended at the assay's limit; the forecaster's own chance of this, stated with the estimate: 30%; middle value at least 2.2-fold (0.34 log units) away from the limit.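

In the HEK293 assay the value of compound 4 is > 100000 nM as a limit of the assay and not a number. Among these compounds, in the HEK293 assay the sulfonyl change gave an at least 2.3-fold lower number from compound 1 to compound 2 (0.36 log units; beyond the scatter), but on the core of compound 3 the matching step cannot be read, so carrying it over is neither confirmed nor ruled out, and the unreadable steps stay unsized because both ends sit at a limit: the limit of > 100000 nM in the HEK293 assay, at which 3 of the 4 values shown sit. In the HEK293 assay the one readable new step is an at least 2.3-fold higher number from compound 2 to compound 4 (0.36 log units; beyond the scatter), for trifluoromethoxy in place of ethyl on an aromatic carbon, while in a physicochemical assay for lipophilicity, read by HPLC, measured as octanol-water partition (on this read-out lower numbers stand for lower lipophilicity and higher numbers for higher lipophilicity), the sulfonyl change gives no change at the digits printed from compound 3 to compound 4 (within the scatter). In the physicochemical assay compound 3 reads 3.4 and compound 4 reads 3.4 as well.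

From the compounds shown here alone, how far the tolerated concentration of the trifluoromethoxy compounds lies past the limit remains open. Also open, going by these compounds, is how a sulfonyl sulfur carrying a 4-aminophenyl or a 4-carboxyphenyl group, rather than methyl or 4-methylphenyl, would read in the HEK293 assay.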